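Oxime ether chain of compound 1 shortened to allyl

The compounds below may be only part of what the source reports. "The series", "measured", "known", "first", "only" and "open" are said of these compounds alone.

compound 1, `CCCO/N=C/c1c(N)ncnc1Oc1ccc2[nH]c(C)cc2c1F`, 30 nM
compound 3, `CO/N=C/c1c(N)ncnc1Oc1ccc2[nH]ccc2c1F`, 365 nM
compound 2, `CO/N=C/c1c(N)ncnc1Oc1ccc2ncccc2c1`, 2870 nM

Of the compounds shown here, three sharing the aminopyrimidine oxime core have been measured in a functional assay on HCT-116 cells (Homo sapiens) for antiproliferative activity; a higher number here means a weaker inhibitor, a lower number a stronger inhibitor. Compound 1 gives the lowest number of the three, 30 nM. Its nearest neighbour is compound 3, which gives 365 nM, a gap that lies beyond the scatter of repeated measurements. Compound 2 gives 2870 nM, the highest number of the set and furthest from compound 1. Going by the values given here, since compound 3 and compound 2 differ from compound 1 in more than one place, no single step between measured compounds can be read from these numbers.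

Compound 4, `C=CCO/N=C/c1c(N)ncnc1Oc1ccc2[nH]c(C)cc2c1F`, has not yet been measured in this assay. It differs from compound 1 in one place: vinyl in place of ethyl on a saturated chain carbon bound to an oxygen on an unsaturated carbon. The change is small and alters neither ring count nor hydrogen-bond donors or acceptors.

Among the compounds with values here, no measured pair shows the effect of this change, so the expectation rests on compound 1 alone, whose 30 nM sets the anchor. Compound 4 is expected to land close to compound 1, with the step from compound 1 to compound 4 estimated at a 1.2-fold higher number from compound 1 to compound 4 (0.07 log units; within the scatter), within the usual scatter in either direction. The estimate for compound 4 is therefore 35 nM, with a range from 12 nM to 100 nM.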

Compound 4, half-maximal inhibitory concentration: 40 nM
Beside the measured number, compound 4's estimate is 1.1-fold (0.06 log units) below it; measured number inside the range.
By their numbers in this assay, from the lowest: compounds 1 and 4 (each within the scatter of the next); then compound 3; then compound 2.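

Going by these compounds alone, this is the first step in this assay that changes only one place: vinyl in place of ethyl on a saturated chain carbon bound to an oxygen on an unsaturated carbon, the difference that also reads propyl to allyl, gives a 1.3-fold higher number from compound 1 to compound 4 (0.12 log units; within the scatter). The step lies within the scatter, so the propyl and allyl chains cannot be told apart in this assay, and this position accepts a double bond outside aromatic rings without a readable loss against the number of the saturated chain. No measurement at hand accounts for this result.

Going by these compounds, what a longer chain such as hexyl, a benzyl group, or a chain ending in an amine or a carboxylic acid would do at this position remains open. On these data alone, compound 2 and compound 3 each differ from compound 1 in more than one place, so the steps among them cannot be read, and the share of the oxime ether chain in their higher numbers stays unknown.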